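The compounds below may be only part of what the source reports. "The series", "measured", "known", "first", "only" and "open" are said of these compounds alone.

Compounds measured in a functional assay on CHO cells with adenosine receptor A1 (Homo sapiens) as the target, read by cAMP accumulation and immunoassay, with a stated time of 6 min, tested at 0.01 uM; on this read-out higher numbers stand for a weaker effect at the one concentration tested and lower numbers for a stronger effect:
- compound 1 `CC(C)N1CCN(Cc2csc(N)c2C(=O)c2ccc(Cl)cc2)CC1` gives -1%
- compound 2 `Nc1scc(CN2CCN(c3ccc(OC(F)(F)F)cc3)CC2)c1C(=O)c1ccc(Cl)cc1` gives 0%

Both numbers sit close to zero, and the two compounds lie within the scatter of each other: the step from compound 1 to compound 2 is a number 1 percentage points higher from compound 1 to compound 2 (within the scatter), so compound 1 stands at one of two essentially indistinguishable readings.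

Compound 3 `Nc1scc(CN2CCN(c3cccnc3)CC2)c1C(=O)c1ccc(Cl)cc1` has not yet been measured in this assay. It differs from compound 1 in one place: pyridin-3-yl in place of isopropyl on an amine nitrogen in a ring. Going by the values given here, the only measured step that bears on this change is the one from compound 1 to compound 2, where a 4-(trifluoromethoxy)phenyl replaced the same isopropyl on the same ring nitrogen; that step was a number 1 percentage points higher from compound 1 to compound 2 (within the scatter), within the scatter. The change to compound 3 likewise puts an aromatic ring on that nitrogen, so the account expects no step beyond the scatter in this assay, and the step from compound 1 to compound 3 is estimated at a number 1 percentage points higher from compound 1 to compound 3 (within the scatter). For compound 3 the expected reading in this assay is therefore 0%, with a range from -10% to 10%.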

Compound 3, a percentage reported as activity, at one concentration (the size of the read-out at that concentration, not a potency): 3.2%
Compound 3: the middle estimate sits 3.2 percentage points below what was measured; the measured number falls inside the stated range.
By their numbers in this assay, from the lowest: compounds 1, 2 and 3 (each within the scatter of the next).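

In this assay, the amine nitrogen in the ring now carries pyridin-3-yl, an aromatic ring with a hetero atom and a hydrogen-bond acceptor, and the step is a number 4.2 percentage points higher from compound 1 to compound 3 (within the scatter), while the step between the two aromatic groups is a number 3.2 percentage points higher from compound 2 to compound 3 (within the scatter). Compound 1 and compound 2 alone showed this only for a carbon-only aromatic ring with a 4-(trifluoromethoxy) group; the present result extends it to an aromatic ring containing nitrogen, so isopropyl, 4-(trifluoromethoxy)phenyl and pyridin-3-yl cannot be told apart at this position on this read-out at the one concentration tested. Nothing available here explains why the three groups read alike.

Going by these compounds, all three compounds give readings near zero at a single concentration, so it remains open whether these groups would separate at other concentrations. On these data alone, it also remains open whether a benzyl group, a longer alkyl chain or a chain ending in a carboxylic acid on the same nitrogen would give a reading beyond the scatter of these three.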